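Dropping the Methoxy Group: An Unmeasured Variant of Compound 3

This account rests on a few compounds, and the source may have more. Where it says the series, first, only, none or still open, it means among the compounds named here.

Compound 1 `C#CCNCc1cc2cc(OC)ccc2n1C` gives 0.813 nM in an assay on isolated protein for inhibition of Amine oxidase [flavin-containing] A (Rattus norvegicus); on this read-out higher numbers stand for weaker inhibition and lower numbers for stronger inhibition.
Compound 2 `c1ccc(CNCc2cn(Cc3ccccc3)c3ccccc23)cc1` gives 245000 nM in this assay.
Compound 3 `CC#CCN(C)Cc1cc2cc(OC)ccc2n1C` gives 1.41 nM in this assay.

Compound 3 holds the second highest of the three numbers. Its nearest neighbour is compound 1, separated by a 1.7-fold higher number from compound 1 to compound 3 (0.24 log units; within the scatter), a gap too small to call a real difference. Compound 2 lies far away at 245000 nM, but it differs from compound 3 in many places at once, so its value says nothing about any single change.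

Compound 4 `CC#CCN(C)Cc1cc2ccccc2n1C` keeps everything in compound 3 except one feature: hydrogen in place of methoxy on an aromatic carbon. Among the measured compounds shown here, the only measured single-place step, a 1.7-fold higher number from compound 1 to compound 3 (0.24 log units; within the scatter), concerns the amine end of the molecule, not the ring, so no measured step bears on this change. The methoxy leaves and a hydrogen enters, and the data give no guidance on what that costs. A modest rise in the number, perhaps still within the scatter, is the cautious expectation, so compound 4 is estimated at 3 nM, between 0.7 nM and 15 nM, meaning a 2.1-fold higher number from compound 3 to compound 4 (0.33 log units; beyond the scatter).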

Compound 4, inhibition constant: 4.27 nM
For compound 4 the middle estimate is 1.4-fold (0.15 log units) below the measured one; low and high end bracket the measured number.
By their numbers in this assay, from the lowest: compounds 1 and 3 (each within the scatter of the next); then compound 4; then compound 2.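

Swapping the methoxy for hydrogen on this aromatic carbon gives a 3.0-fold higher number from compound 3 to compound 4 (0.48 log units; beyond the scatter) in this assay, the first step here that lies beyond the scatter and the first to touch the ring rather than the amine end. The step is modest, and compound 4 still gives 4.27 nM with no methoxy at all, so among these compounds a low number does not depend on that group. Nothing measured here explains why the number rises.

Still open, going by these compounds, is how other groups on this same carbon would compare, such as an ethoxy group, a hydroxyl or a fluorine atom. On these data alone, it is also open whether losing the methoxy would cost the same with the propargylamino end of compound 1 in place of the (but-2-yn-1-yl)(methyl)amino end.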